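Changing the Aryl Group Attached to the Shared Core

A few compounds are considered here, and "the series" means these few. Any claim that something is new, unique, unknown or untested is made for them only; others in the source may bear on it.

Compound 1 `CCCS(=O)(=O)Nc1ccc(F)c(C(=O)c2n[nH]c3ncc(-c4ccccc4C)cc23)c1F` and compound 2 `CCCS(=O)(=O)Nc1ccc(F)c(C(=O)c2n[nH]c3ncc(-c4ccc(O)cc4)cc23)c1F` share a common core and differ only in the aromatic ring attached to it. In an assay for binding affinity to dual specificity mitogen-activated protein kinase kinase 4 (Homo sapiens), read by KINOMEscan, tested at 100 nM (on this read-out lower numbers stand for a stronger effect and higher numbers for a weaker effect at the one concentration tested), compound 1 gives 7%, while compound 2 gives 0.75%. Compound 1 thus holds the higher of the two numbers, but the step of a number 6.3 percentage points lower from compound 1 to compound 2 (within the scatter) lies within the scatter, so the two values cannot be told apart. Compound 3 `CCCS(=O)(=O)Nc1ccc(F)c(C(=O)c2n[nH]c3ncc(-c4ccc(C(C)(C)C)cc4)cc23)c1F` differs from compound 1 by 4-(tert-butyl)phenyl in place of 2-methylphenyl on an aromatic carbon. For the measured compounds named here, the only measured step that bears on this change is the one from compound 1 to compound 2, which also replaced the 2-methylphenyl group and left the read-out essentially where it was. On that basis no step beyond the scatter is expected for compound 3 in this assay. Compound 3 is therefore expected to give about 8%, within a range from 1% to 30%. This amounts to an expected step of a number 1 percentage points higher from compound 1 to compound 3 (within the scatter).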

Compound 3, a percentage reported as activity, at one concentration (the size of the read-out at that concentration, not a potency): 46%
The estimate for compound 3 lay 38 percentage points below the measured number; the whole stated range lies below it.
By their numbers in this assay, from the lowest: compounds 2 and 1 (each within the scatter of the next); then compound 3.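

The position on the shared core is therefore not indifferent to the aryl group it carries in this assay: 4-(tert-butyl)phenyl in place of 2-methylphenyl gives a number 39 percentage points higher from compound 1 to compound 3 (beyond the scatter), whereas 4-hydroxyphenyl in place of the same group had left a step within the scatter. The change on the phenyl ring itself, tert-butyl in place of hydroxy, gives a number 45.3 percentage points higher from compound 2 to compound 3 (beyond the scatter), which shows that the read-out here depends on the group the ring carries and not merely on an aryl ring being present. Nothing available explains either step.

The compounds shown leave open whether this large step is particular to tert-butyl or would also appear with other groups on the ring, such as a methoxy group, an amine or a carboxylic acid. They also leave open how a 3-(tert-butyl)phenyl group would read at this position.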